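Urea series: removing one trifluoromethyl from the terminal ring

This account rests on a few compounds, and the source may have more. Where it says the series, first, only, none or still open, it means among the compounds named here.

Compound 3 `COc1cc(Cl)cc(-c2nn(-c3cccc(NC(=O)Nc4cc(C(F)(F)F)cc(C(F)(F)F)c4)c3)cc2-c2ccncc2)c1` stands second highest of the three numbers in a functional assay on RXF 393 cells (Homo sapiens) for inhibition, read by sulforhodamine B assay, with a stated time of 48 h, tested at 1 uM (a lower number here means a stronger effect, a higher number a weaker effect of the compound at the concentration tested), where compound 3 gives 50%. Nearest is compound 1 `O=C(Nc1cccc(-n2cc(-c3ccncc3)c(-c3cc(O)cc(Cl)c3)n2)c1)Nc1ccc(Cl)c(C(F)(F)F)c1`, which in this assay gives 58%; that gap is within the scatter. Furthest is compound 2 `O=C(Nc1cccc(-n2cc(-c3ccncc3)c(-c3cc(O)cc(Cl)c3)n2)c1)Nc1ccc(Cl)c(Cl)c1`, which in this assay gives 38%, a gap from compound 3 beyond the scatter. Among the measured compounds shown here, the only step among measured pairs is a number 20 percentage points lower from compound 1 to compound 2 (beyond the scatter), which moved the number toward a stronger effect. Compound 4 `COc1cc(Cl)cc(-c2nn(-c3cccc(NC(=O)Nc4cccc(C(F)(F)F)c4)c3)cc2-c2ccncc2)c1` differs from compound 3 by hydrogen in place of trifluoromethyl on an aromatic carbon. For the measured compounds named here, no measured pair replaces a trifluoromethyl with hydrogen; the step from compound 1 to compound 2 exchanges it for chloro and on a differently substituted ring, so it bears only loosely here. With a group removed rather than swapped, no step beyond the scatter is expected in this assay, with at most a slight drift toward a weaker effect. Compound 4 is therefore expected to give 55%, within 35% to 75%. The expected step is a number 5 percentage points higher from compound 3 to compound 4 (within the scatter).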

Compound 4, a percentage reported as activity, at one concentration (the size of the read-out at that concentration, not a potency): 68%
The estimate for compound 4 lay 13 percentage points below the measured number, and the stated range covers the measured number.
By their numbers in this assay, from the lowest: compound 2; then compounds 3, 1 and 4 (each within the scatter of the next, the first and the last beyond it).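

Removing one trifluoromethyl from the terminal ring gives a number 18 percentage points higher from compound 3 to compound 4 (beyond the scatter) in this assay and so moves the number toward a weaker effect. The earlier step, a number 20 percentage points lower from compound 1 to compound 2 (beyond the scatter) on a differently substituted ring, showed only that exchanging trifluoromethyl for chloro can go with a stronger effect; this pair adds that outright loss of the group, with hydrogen left in its place, goes the other way in this series. Nothing measured in this set gives a reason for the step.

As far as these compounds go, whether a nitrile or an amine in this place, with the other trifluoromethyl kept, would hold the number of compound 3 stays open. Also open, from the compounds shown here alone, is whether the same removal would read alike on the core of compound 1.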